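Shortening the Side Chain in a Quinolinylmethoxyphenyl Butanoic Acid Series

A few compounds are considered here, and "the series" means these few. Any claim that something is new, unique, unknown or untested is made for them only; others in the source may bear on it.

For the measured compounds named here, compound 2 `CCCC(CCC(=O)O)Cc1ccc(OCc2ccc3ccccc3n2)cc1` stands at the lowest of the two numbers so far recorded in a functional assay (lung) for inhibition, with Cavia porcellus as the target (on this read-out lower numbers stand for stronger inhibition and higher numbers for weaker inhibition), where compound 2 gives 30 nM. Its nearest neighbour is compound 1 `O=C(O)CCC(Cc1ccc(OCc2ccc3ccccc3n2)cc1)c1ccccc1`, which in this assay gives 65 nM; the step of a 2.2-fold lower number from compound 1 to compound 2 (0.34 log units; beyond the scatter) is modest but beyond the scatter. Compound 3 `CC(CCC(=O)O)Cc1ccc(OCc2ccc3ccccc3n2)cc1` differs from compound 2 by hydrogen in place of ethyl on a saturated chain carbon, three bonds along the chain from an aromatic carbon. Going by the values given here, no measured step addresses this kind of trimming: the only step on record exchanges phenyl for propyl at the same position, which is a different change. On the evidence at hand a weakening in this assay seems likelier than a gain, though a step no larger than the scatter cannot be ruled out. Compound 3 is therefore estimated at 70 nM in this assay, with a plausible range from 25 nM to 200 nM. This estimate corresponds to an expected step of a 2.3-fold higher number from compound 2 to compound 3 (0.37 log units; beyond the scatter).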

Compound 3, half-maximal inhibitory concentration: 100 nM
Compound 3: the middle estimate sits 1.4-fold (0.15 log units) below what was measured; measured number inside the range.
By their numbers in this assay, from the lowest: compound 2; then compounds 1 and 3 (each within the scatter of the next).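

In this assay, the size of the group on the saturated chain carbon, three bonds along the chain from an aromatic carbon, proves to matter: with hydrogen in place of ethyl, which cut one bond further out reads propyl to methyl, there is a 3.3-fold higher number from compound 2 to compound 3 (0.52 log units; beyond the scatter), a modest loss. Methyl and phenyl at this carbon give values that cannot be told apart, with a 1.5-fold higher number from compound 1 to compound 3 (0.19 log units; within the scatter), so among these three compounds only the propyl of compound 2 stands clear of the other two. Nothing available accounts for this difference.

The compounds shown do not reveal how an ethyl, a butyl or a longer chain at this carbon would compare with propyl. Nor do they show what a chain ending in an amine or a hydroxyl group would do here.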